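This account rests on a few compounds, and the source may have more. Where it says the series, first, only, none or still open, it means among the compounds named here.

Compound 1 `CSCC[C@H](NC(=O)c1ccc(NCc2cncn2Cc2cccc(C)c2)cc1-c1ccccc1)C(=O)O` stands at a limit in a functional assay on NIH3T3 cells (Mus musculus); a lower number here means that less compound is needed, a higher number that more compound is needed for the effect: compound 1 gives > 10 uM, a limit of the assay and not a number. Compound 2 `CSCC[C@H](NC(=O)c1ccc(NCc2cncn2Cc2cccc(C#N)c2)cc1-c1ccccc1)C(=O)O` is likewise at a limit; in this assay compound 2 gives > 10 uM. In this assay a step that the two limits leave unreadable from compound 1 to compound 2, cyano in place of methyl on an aromatic carbon, both values sitting at the limit of > 10 uM in this assay, at which 2 of the 2 values shown sit. Compound 3 `COC(=O)[C@H](CCSC)NC(=O)c1ccc(NCc2cncn2Cc2cccc(C)c2)cc1-c1ccccc1` differs from compound 1 by methyl in place of hydrogen on an oxygen next to a carbonyl group. Within the data shown here, no measured step covers this change, and the one measured step is unreadable, so no shift beyond the scatter is expected. In this assay the step from compound 1 to compound 3 is expected to be a step that the limit leaves unreadable from compound 1 to compound 3. Compound 3 is estimated at 15 uM, within 5 uM to 50 uM, most likely reported again only as a limit.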

Compound 3, concentration for half-maximal effect: > 10 uM
Compound 3 ended at the assay's limit (the forecaster's own chance of this, stated with the estimate: 70%); the middle value is on the limit's open side.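

Compound 3 sits at a limit of the assay like compound 1, so no step between them can be read: the limit of > 10 uM in this assay, at which 3 of the 3 values shown sit.

The compounds shown leave open whether cyano for methyl or methoxycarbonyl for carboxy shifts the concentration needed in this assay at all.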